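From compound 3 to compound 4: a benzyl exchange

The source may hold more compounds than are shown below. What is called first, only, known or untested is meant among the compounds shown, and "the series" means these compounds.

In a functional assay on HeLa cells (Homo sapiens) for antiproliferative activity, read by MTT assay, with a stated time of 48 h (a higher number here means a weaker inhibitor, a lower number a stronger inhibitor), compound 1 (`Fc1ccccc1CSc1nnc(-c2cnccn2)o1`) gives 25300 nM and compound 2 (`Brc1cccc(CSc2nnc(-c3cnccn3)o2)c1`) gives 30300 nM in the same read-out, two values within the usual scatter of each other. Compound 3 (`Clc1ccccc1CSc1nnc(-c2cnccn2)n1-c1ccccc1`) is reported only as > 50000 nM in this assay and this is a limit of the assay, not a number. Compound 3 therefore stands at the limit of > 50000 nM in this assay, at which 1 of the 3 values shown sits, and offers no exact starting value.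

Compound 4 (`Fc1ccc(CSc2nnc(-c3cnccn3)n2-c2ccccc2)cc1`) carries 4-fluorophenyl in place of 2-chlorophenyl on a saturated chain carbon bound to a sulfur. The same difference reads as 2-chlorobenzyl to 4-fluorobenzyl.

Going by the values given here, no measured pair differs in one place only, so the size of this step has no direct precedent. The estimated step of an at least 1.1-fold lower number from compound 3 to compound 4 (0.04 log units; that floor lies within the scatter) is expected to stay within the usual scatter, with no direction favoured. The expectation rests on compound 3 with its limit of > 50000 nM as the only starting point. A report of compound 4 as a limit is thought about as likely as a number. Compound 4 is expected in this assay at 45000 nM with an estimated range (18000 nM to 80000 nM).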

Compound 4, half-maximal inhibitory concentration: 7300 nM
Compound 4: middle estimate off by 6.2-fold (0.79 log units), on the high side, and the stated range ends above it.
By their numbers in this assay, from the lowest: compound 4; then compounds 1 and 2 (each within the scatter of the next). At a limit, above all of these: compound 3.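

In this assay, going by these compounds alone, the change from 2-chlorophenyl to 4-fluorophenyl on a saturated chain carbon bound to a sulfur is the first change in one place that can be read, and it gives an at least 6.8-fold lower number from compound 3 to compound 4 (0.83 log units; beyond the scatter). Within the data shown here, the group held at this place is therefore not silent: swapping it alone moves the read-out beyond the scatter, which no earlier pair could show. Compound 3 is reported as > 50000 nM, which is a limit of the assay and not a number, so the size of the step is known only as a floor: the limit of > 50000 nM in this assay, at which 1 of the 4 values shown sits.

The halogen and its place on the phenyl ring change together in this single step, and the compounds shown do not separate the two contributions. Going by these compounds, whether a longer chain at this place, or an amine on the phenyl ring in place of the halogen, would keep the lower number of compound 4 also remains open.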